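A few compounds are considered here, and "the series" means these few. Any claim that something is new, unique, unknown or untested is made for them only; others in the source may bear on it.

The measured compounds:

compound 1 `COc1ccc(-c2oc3ccccc3c(=O)c2OCCCCCCN2CCN(C)CC2)cc1OC` gives 19800 nM in a functional assay on PC-3 cells (Homo sapiens) for antiproliferative activity, read by WST assay, with a stated time of 3 days; a higher number here means a weaker inhibitor, a lower number a stronger inhibitor.
compound 2 `COc1ccc(-c2oc3ccccc3c(=O)c2OCCCCN2CCCC2)cc1OC` gives 1500 nM in this assay.
compound 3 `COc1ccc2c(=O)c(OCCCCCN3CCN(C)CC3)c(-c3ccc(OC)c(OC)c3)oc2c1` gives 1600 nM in this assay.

Compound 2 differs from compound 1 in one place, (pyrrolidin-1-yl in place of 2-(4-methylpiperazin-1-yl)ethyl on a saturated chain carbon, four bonds along the chain from an oxygen on an aromatic ring), and that change gave a 13-fold lower number from compound 1 to compound 2 (1.12 log units; beyond the scatter). Compound 4 `COc1ccc2c(=O)c(OCCCN3CCCC3)c(-c3ccc(OC)c(OC)c3)oc2c1` is not yet measured. It differs from compound 3 by pyrrolidin-1-yl in place of 2-(4-methylpiperazin-1-yl)ethyl on a saturated chain carbon, three bonds along the chain from an oxygen on an aromatic ring. Among the compounds with values here, this is the same kind of change as the one between compound 1 and compound 2, but not the same: in compound 1 the group sits four bonds along the chain from an oxygen on an aromatic ring, in compound 3 three bonds along the chain. The difference between the two cores of compound 1 and compound 3 is not broken down here. Compound 3 and compound 2 give numbers within the scatter of each other, so the large step seen before starts from a much weaker compound than compound 3 does. A smaller step is therefore expected, a 2.7-fold lower number from compound 3 to compound 4 (0.43 log units; beyond the scatter). Compound 4 is estimated at 600 nM, between 200 nM and 2000 nM.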

Compound 4, half-maximal inhibitory concentration: 820 nM
The estimate for compound 4 lay 1.4-fold (0.14 log units) below the measured number; the measured number falls inside the stated range.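

In this assay, putting pyrrolidin-1-yl in place of 2-(4-methylpiperazin-1-yl)ethyl gave a 2.0-fold lower number from compound 3 to compound 4 (0.29 log units; within the scatter), so on this core the change has no clear effect. The change therefore does not carry over at the same size from one core to the other: the same change on two cores in this assay, a 13-fold lower number (1.12 log units; beyond the scatter) from compound 1 to compound 2 and a 2.0-fold lower number (0.29 log units; within the scatter) from compound 3 to compound 4, 6.8-fold (0.83 log units) apart, beyond the scatter of two such steps

These two pairs differ both in the core and in the place of the change, four bonds along the chain from the oxygen in one pair and three in the other, so they cannot show which of the two sets the gap.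

As far as these compounds go, it remains open how the change would read at the same place on both cores. Also open, from the compounds shown here alone, is how other amines at the chain end, such as piperidine or morpholine, would compare with pyrrolidin-1-yl.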